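The compounds below may be only part of what the source reports. "The series", "measured", "known", "first", "only" and "open" are said of these compounds alone.

Compound 2 `CCOc1cccc2c1S(=O)(=O)N=C2C1=C(O)[C@H](C(C)C)N(Cc2ccccc2)C1=O` and compound 1 `CC(C)[C@H]1C(O)=C(C2=NS(=O)(=O)c3ccccc32)C(=O)N1Cc1ccccc1` share one core and differ only by an ethoxy in place of hydrogen on an aromatic carbon. In an in vitro ADME assay on microsomes from liver (Homo sapiens) for metabolic stability (on this read-out lower numbers stand for a shorter-lived compound and higher numbers for a longer-lived compound), compound 1 gives a value that is a limit of the assay, > 1 h. In this assay compound 2 likewise gives only a limit, > 1 h. The step that the two limits leave unreadable from compound 1 to compound 2 is therefore not readable, since (the limit of > 1 h in this assay, at which 2 of the 2 values shown sit).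

Compound 3 `CC(C)[C@H]1C(O)=C(C2=NS(=O)(=O)c3c(O)cccc32)C(=O)N1Cc1ccccc1` arises from compound 2 by a single change, (hydrogen in place of ethyl on an oxygen on an aromatic ring). Among the measured compounds shown here, no measured step bears on this change, and the only comparison available sits at the limit at both ends, so it sets no direction and no size. The step that the limit leaves unreadable from compound 2 to compound 3 is expected to stay within the usual scatter, in either direction. For compound 3 the half-life in this assay is estimated at 1.2 h, within a range from 0.5 h to 3 h.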

Compound 3, half-life: > 1 h
Compound 3 gave a limit, no number; the forecaster's own chance of this, stated with the estimate: 60%; the middle value does not contradict the limit.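

Compound 3 also gives only a limit in this assay, > 1 h. No step among compound 1, compound 2 and compound 3 can therefore be read: the limit of > 1 h in this assay, at which 3 of the 3 values shown sit.

The compounds shown leave open whether ethoxy or hydroxy in place of hydrogen changes the half-life at all.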